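Swapping Nitrophenyl for Chlorophenyl: Expected Effect on Cytotoxicity

The source may hold more compounds than are shown below. What is called first, only, known or untested is meant among the compounds shown, and "the series" means these compounds.

Measured compounds:
Compound 1 `CC(=O)OC[C@H]1O[C@H](OC[C@H](Cn2cc(COc3ccc(-c4noc(NC5CCCCC5)n4)cc3)nn2)OC(C)=O)C=C[C@@H]1OC(C)=O` in an ADME assay on HepG2 cells (Homo sapiens) for cytotoxicity, read by MTT assay, with a stated time of 48 h; on this read-out higher numbers stand for lower toxicity in this test and lower numbers for higher toxicity in this test: 99.5 ug/mL.
Compound 2 `CC(=O)OC[C@H]1O[C@H](OC[C@@H](Cn2cc(CN(c3nc(-c4cccc([N+](=O)[O-])c4)no3)C3CCCCC3)nn2)OC(C)=O)C=C[C@@H]1OC(C)=O`: > 200 ug/mL, which is a limit of the assay and not a number.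

In this assay compound 2 therefore sits at the upper edge of what was measured, as shown by the limit of > 200 ug/mL in this assay, at which 1 of the 2 values shown sits. Going by the values given here, compound 1 gives a number below that edge, but the two compounds differ in more than one place, so no single step between them can be read from their values.

Compound 3 `CC(=O)OC[C@H]1O[C@H](OC[C@@H](Cn2cc(CN(c3nc(-c4ccc(Cl)cc4)no3)C3CCCCC3)nn2)OC(C)=O)C=C[C@@H]1OC(C)=O` differs from compound 2 in one place: 4-chlorophenyl in place of 3-nitrophenyl on an aromatic carbon. No measured step of this kind is available among these compounds, and nothing in the data points in either direction, so the step of a number no higher from compound 2 to compound 3 (the limit leaves the size open) is expected to stay within the usual scatter. Compound 3 is expected to give 200 ug/mL in this assay, with a range from 90 ug/mL to 400 ug/mL, and quite possibly again only a limit.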

Compound 3, half-maximal cytotoxic concentration: 46.9 ug/mL
Beside the measured number, compound 3's estimate is 4.3-fold (0.63 log units) above it; the measured number lies below the stated range.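

In this assay, going by these compounds alone, this swap on an aromatic carbon of the five-membered ring is the first change that can be read on its own, and it gives an at least 4.2-fold lower number from compound 2 to compound 3 (0.62 log units; beyond the scatter). The group at this position therefore matters: 4-chlorophenyl in place of 3-nitrophenyl moves the read-out towards higher toxicity in this test, beyond the usual scatter. The true size of the step stays unknown, since compound 2 carries a limit of the assay and not a number: the limit of > 200 ug/mL in this assay, at which 1 of the 3 values shown sits.

The compounds shown leave open whether the chlorine atom, the nitro group or both account for the step, as one whole substituted phenyl replaces another. Going by these compounds, how this position would respond to an unsubstituted phenyl, or to an amine or a carboxylic acid in place of the ring, also stays unknown.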